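Replacing 4-chlorophenyl with thiophen-2-yl in compound 3

The source may report more compounds than this note shows. Statements on the series, on what has been measured and on what is new or still open speak of the compounds shown alone.

Within the data shown here, in a functional assay on HEY cells (Homo sapiens) for cytotoxicity, read by MTT assay, with a stated time of 72 h (a higher number here means a weaker inhibitor, a lower number a stronger inhibitor), compound 3 `N[C@H]1CC[C@H](Nc2c(C(=O)NCc3ccc(Cl)cc3)nc(Br)c3cccnc23)CC1` gives 1000 nM, the lowest number so far. Compound 1 `CN(C)c1ccc(CNC(=O)c2nc(Br)c3cccnc3c2N[C@H]2CC[C@H](N)CC2)cc1` gives 5300 nM. Compound 2 `C[C@H](NC(=O)c1nc(Br)c2cccnc2c1N[C@H]1CC[C@H](N)CC1)c1ccc(F)cc1` reads > 10000 nM, which is a limit of the assay and not a number.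

Compound 4 `N[C@H]1CC[C@H](Nc2c(C(=O)NCc3cccs3)nc(Br)c3cccnc23)CC1` has thiophen-2-yl in place of 4-chlorophenyl on a saturated chain carbon bound to an amide-type nitrogen.

Among the measured compounds shown here, two measured steps bear on this change, since both alter the group on the amide nitrogen: a 5.3-fold lower number from compound 1 to compound 3 (0.72 log units; beyond the scatter) and an at least 10-fold lower number from compound 2 to compound 3 (1.00 log units; beyond the scatter). For the measured compounds named here, both favour the 4-chlorobenzyl group, and no compound so far goes against this. Neither step involves thiophen-2-yl, so the size of the new step remains uncertain. Leaving 4-chlorobenzyl is therefore expected to give a higher number in this assay, but a smaller change than those two steps. The expected change is a 2.5-fold higher number from compound 3 to compound 4 (0.40 log units; beyond the scatter). Compound 4 is estimated at 2500 nM, with an expected range of 800 nM to 9000 nM.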

Compound 4, half-maximal inhibitory concentration: 11000 nM
Estimate against measurement, compound 4: 4.4-fold (0.64 log units) below, and the stated range ends below it.
By their numbers in this assay, from the lowest: compound 3; then compound 1; then compound 4.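

In this assay, the 4-chlorophenyl group on a saturated chain carbon bound to an amide-type nitrogen does not tolerate exchange for thiophen-2-yl, with an 11-fold higher number from compound 3 to compound 4 (1.04 log units; beyond the scatter) as the cost of the change. The smaller ring also falls behind the 4-(dimethylamino)phenyl group, with a 2.1-fold higher number from compound 1 to compound 4 (0.32 log units; beyond the scatter) in the same assay, so among the three readable groups at this position, 4-chlorophenyl alone gives the lowest number. Compound 2 stands at a limit and not a number, so its step to compound 4 cannot be read: the limit of > 10000 nM in this assay, at which 1 of the 4 values shown sits.

As far as these compounds go, whether the loss goes with the chloro group or with the change of ring stays open. Benzyl and (5-chlorothiophen-2-yl)methyl on the same nitrogen would separate the two.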